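A few compounds are considered here, and "the series" means these few. Any claim that something is new, unique, unknown or untested is made for them only; others in the source may bear on it.

Working notes on the series. The shared core is seen in compound 1 `CCS(=O)(=O)c1ccc(CNC(=O)c2ccc3c(c2)cc(Cc2ccc(Cl)cc2C(F)(F)F)n3C(C)C)cc1` and compound 2 `CCc1ccccc1Cc1cc2cc(C(=O)NCc3ccc(S(=O)(=O)CC)cc3)ccc2n1C(C)C`. In an ADME assay on microsomes from liver (Rattus norvegicus) for metabolic stability (on this read-out lower numbers stand for a shorter-lived compound and higher numbers for a longer-lived compound), compound 1 gives 1.93 h, and compound 2 gives 0.2 h. Within the data shown here, the only recorded step is a 9.7-fold lower number from compound 1 to compound 2 (0.98 log units; beyond the scatter), where the change sits on a saturated chain carbon bound to an aromatic carbon. Among the measured compounds shown here, on the two numbers so far compound 2 stands lowest, with compound 1 its only neighbour, above it by that step and beyond the scatter.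

Compound 3 `CCS(=O)(=O)c1ccc(CNC(=O)c2ccc3c(c2)cc(Cc2ccc(F)cc2C(F)(F)F)n3C(C)C)cc1` is not yet measured in this assay. Its difference from compound 2 is 4-fluoro-2-(trifluoromethyl)phenyl in place of 2-ethylphenyl on a saturated chain carbon bound to an aromatic carbon. The group entering in compound 3 closely resembles the 4-chloro-2-(trifluoromethyl)phenyl that left in the step from compound 1 to compound 2, a fluorine standing where that group carried chlorine, with the trifluoromethyl retained. The step that bears on this change is a 9.7-fold lower number from compound 1 to compound 2 (0.98 log units; beyond the scatter), and its reverse is expected here, so a rise of about that size, a 7.5-fold higher number from compound 2 to compound 3 (0.88 log units; beyond the scatter), is expected. Compound 3 is accordingly estimated at 1.5 h, within a range of 0.6 h to 3.5 h.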

Compound 3, half-life: 1.07 h
For compound 3 the middle estimate is 1.4-fold (0.15 log units) above the measured one, and the stated range covers the measured number.
By their numbers in this assay, from the lowest: compound 2; then compounds 3 and 1 (each within the scatter of the next).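

In this assay, a second group carrying trifluoromethyl and a halogen on this saturated chain carbon also stands clear of 2-ethylphenyl, with a 5.4-fold higher number from compound 2 to compound 3 (0.73 log units; beyond the scatter) and so beyond the scatter; the low number of compound 2 is thus set against two partners rather than one. The change inside the group, fluoro in place of chloro on an aromatic carbon, gives a 1.8-fold lower number from compound 1 to compound 3 (0.26 log units; within the scatter) and stays within the scatter, so this read-out does not separate the two halogens in this pair. Nothing measured on hand speaks to what lies behind either step. 

Compound 2 differs from compound 3 both in carrying ethyl where compound 3 carries trifluoromethyl and in lacking the fluoro, so the compounds shown do not divide the step between these two features; a phenyl bearing trifluoromethyl alone, or one bearing ethyl together with fluoro, would be needed to divide it. As far as these compounds go, whether a nitrile or a methoxy group in place of the halogen would give a number like those of compound 1 and compound 3 also remains open.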